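The source may report more compounds than this note shows. Statements on the series, on what has been measured and on what is new or still open speak of the compounds shown alone.

Measured so far:
compound 1, `CCCC(=O)N1CC2CC(C1)N2` — 580 nM
compound 2, `O=C([C@@H]1C[C@@H]1F)N1CC2CC(C1)N2` — 120 nM
compound 3, `C[C@@H]1C[C@@H]1C(=O)N1CC2CC(C1)N2` — 2100 nM

These three compounds share one core and differ only in the group on the carbonyl carbon. In an assay on SH-EP1 cells for agonist activity at Neuronal acetylcholine receptor; alpha4/beta2 (Homo sapiens), read by FLIPR and calcium flux (a lower number here means that less compound is needed, a higher number that more compound is needed for the effect), compound 1 stands second highest of the three numbers. Going to compound 2 gave a 4.8-fold lower number from compound 1 to compound 2 (0.68 log units; beyond the scatter), and going to compound 3 gave a 3.6-fold higher number from compound 1 to compound 3 (0.56 log units; beyond the scatter); between those two ring-bearing compounds the gap was an 18-fold higher number from compound 2 to compound 3 (1.24 log units; beyond the scatter).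

Compound 4, `C[C@H]1C[C@@H]1C(=O)N1CC2CC(C1)N2`, has not been measured yet. It differs from compound 1 in one place: 2-methylcyclopropyl in place of propyl on a carbonyl carbon. Compound 3 also carries a 2-methylcyclopropyl, arranged differently at its two stereocentres, so the step from compound 1 to compound 3 bears most directly on this one, while the step from compound 1 to compound 2 shows that a small ring in this place can also lower the number.

For compound 4 in this assay, a modest step upward from compound 1 is expected, a 2.1-fold higher number from compound 1 to compound 4 (0.32 log units; beyond the scatter), because compound 3 gave 2100 nM. The estimate for compound 4 is therefore 1200 nM, within a range from 300 nM to 4500 nM.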

Compound 4, half-maximal effective concentration: 9100 nM
Compound 4: middle estimate off by 7.6-fold (0.88 log units), on the low side; measured number above the stated range.
By their numbers in this assay, from the lowest: compound 2; then compound 1; then compound 3; then compound 4.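

In this assay, the arrangement at a single ring carbon of the 2-methylcyclopropyl group counts: with the same atoms and bonds, the result is a 4.3-fold higher number from compound 3 to compound 4 (0.64 log units; beyond the scatter), so the group's name alone does not settle the number at this place on the carbonyl carbon. With this arrangement, replacing propyl gives a 16-fold higher number from compound 1 to compound 4 (1.20 log units; beyond the scatter), and replacing 2-fluorocyclopropyl with 2-methylcyclopropyl gives a 76-fold higher number from compound 2 to compound 4 (1.88 log units; beyond the scatter), a far wider spread among these small groups than the earlier compounds showed. The comparison of the two methyl-bearing compounds carries one caution: the fact that one of compounds 3 and 4 is drawn with a defined configuration and the other without, at the place where they differ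

As far as these compounds go, it remains open whether 2-fluorocyclopropyl responds to a change of arrangement in the same way as 2-methylcyclopropyl. Also open, from the compounds shown here alone, is where a plain cyclopropyl or a longer chain such as pentyl would fall in this assay.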